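Adding a Methoxy Where All Three Compounds Sit at a Limit

The compounds below may be only part of what the source reports. "The series", "measured", "known", "first", "only" and "open" are said of these compounds alone.

Of the compounds shown here, three have been measured in an ADME assay on HUVEC cells (Homo sapiens) for antiproliferative activity, read by MTT assay, with a stated time of 48 h; a higher number here means a weaker inhibitor, a lower number a stronger inhibitor. In this assay compound 1 `Cc1cccc(-n2nncc2CN2C(=O)C3(C(C#N)=C(N)Oc4c3c3nc5ccccc5nc3c3ccccc43)c3ccccc32)c1` gives > 50000 nM, which is a limit of the assay and not a number. Compound 2 `COc1ccccc1-n1nncc1CN1C(=O)C2(C(C#N)=C(N)Oc3c2c2nc4ccccc4nc2c2ccccc32)c2ccccc21` carries 2-methoxyphenyl in place of 3-methylphenyl on an aromatic nitrogen, and in this assay compound 2 gives > 50000 nM, again a limit. The step that the two limits leave unreadable from compound 1 to compound 2 is therefore unreadable. In this assay compound 3 `COc1ccccc1-n1nncc1CN1C(=O)C2(C(C#N)=C(N)Oc3c(N)cc4nc5ccccc5nc4c32)c2ccccc21` gives > 50000 nM, also a limit, so compound 3 stands exactly where the other two stand, as the limit of > 50000 nM in this assay, at which 3 of the 3 values shown sit, records.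

Compound 4 `COc1ccc(OC)c(-n2nncc2CN2C(=O)C3(C(C#N)=C(N)Oc4c(N)cc5nc6ccccc6nc5c43)c3ccccc32)c1` has not yet been measured. It differs from compound 3 by methoxy in place of hydrogen on an aromatic carbon; cut one bond further out, the change reads 2-methoxyphenyl to 2,5-dimethoxyphenyl. Among the compounds with values here, no measured step bears on this change, since the only step recorded is unreadable and every value sits at the same limit. The step that the limit leaves unreadable from compound 3 to compound 4 is therefore expected to be none beyond the scatter. Compound 4 is expected to give 60000 nM, within 20000 nM to 200000 nM, and most probably to be reported as a limit once more.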

Compound 4, half-maximal inhibitory concentration: > 50000 nM
Compound 4 gave a limit, no number (the forecaster's own chance of this, stated with the estimate: 85%); the middle value is on the limit's open side.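

In this assay compound 4 gives > 50000 nM, a limit and not a number, so the step from compound 3 to compound 4 cannot be read. The compounds shown leave open what actual value any of them would give, as all rest on one limit: the limit of > 50000 nM in this assay, at which 4 of the 4 values shown sit.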